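Adding a second methyl to the aryl ring of compound 1

The source may report more compounds than this note shows. Statements on the series, on what has been measured and on what is new or still open speak of the compounds shown alone.

Of the compounds shown here, three sharing one core have been measured in a functional assay on KBVIN cells (Homo sapiens) for antiproliferative activity, read by sulforhodamine B assay, with a stated time of 3 days; on this read-out higher numbers stand for an effect only at larger amounts of compound and lower numbers for an effect already at smaller amounts. Compound 1 `CCC1=C(O)c2c(oc(-c3cccc(C)c3)cc2=O)C(CC)(CC)C1=O` gives 3.69 uM, the highest of the three numbers. Compound 2 `CCC1=C(O)c2c(oc(-c3ccc(OC)c(OC)c3)cc2=O)C(CC)(CC)C1=O` gives 1 uM, and compound 3 `CCC1=C(O)c2c(oc(-c3ccc(OC)c(OC)c3OC)cc2=O)C(CC)(CC)C1=O` gives 1.57 uM. Compound 1 thus sits beyond the scatter above both of them.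

Compound 4 `CCC1=C(O)c2c(oc(-c3cccc(C)c3C)cc2=O)C(CC)(CC)C1=O` differs from compound 1 by methyl in place of hydrogen on an aromatic carbon, the new group sitting ortho to a methyl group on the aryl ring.

Going by the values given here, no measured step adds a methyl to this ring. Among the compounds with values here, the only step that resembles it in kind, a small group entering an aromatic carbon, is a 1.6-fold higher number from compound 2 to compound 3 (0.20 log units; within the scatter), which stayed within the scatter. Within the data shown here, with no direct precedent and the one comparable step showing no real movement, compound 4 is expected to stay close to compound 1 in this assay, with the change a 1.1-fold lower number from compound 1 to compound 4 (0.02 log units; within the scatter) estimated to remain within the scatter.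

Compound 4 is therefore estimated at 3.5 uM, with a likely range from 1.5 uM to 8 uM.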

Compound 4, concentration for half-maximal effect: 0.85 uM
Beside the measured number, compound 4's estimate is 4.1-fold (0.61 log units) above it; measured number below the stated range.
By their numbers in this assay, from the lowest: compounds 4, 2 and 3 (each within the scatter of the next); then compound 1.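

Moving from 3-methylphenyl to 2,3-dimethylphenyl, a single added methyl gives a 4.3-fold lower number from compound 1 to compound 4 (0.64 log units; beyond the scatter) in this assay. The only earlier step, the methoxy change with a 1.6-fold higher number from compound 2 to compound 3 (0.20 log units; within the scatter), stayed within the scatter, so this is the first step shown in which one added group clearly shifts the number, here ortho to a methyl group on the aryl ring. No measurement offered here explains why the number falls with this change.

The compounds shown leave open whether this aromatic carbon favours methyl in particular or would respond similarly to an ethyl group, a chlorine atom or an amine. As far as these compounds go, it also remains open whether the step depends on the methyl group already on the ring of compound 1.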